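Adding a Methyl Group to the Chlorinated Aromatic Ring

The compounds below may be only part of what the source reports. "The series", "measured", "known", "first", "only" and "open" are said of these compounds alone.

Compound 1 `CCC(=O)N(c1ccc(Cl)cc1)C1CCCC1N(C)C` gives 0.2 mg/kg in a functional assay on the whole organism for antagonist activity, with Mus musculus as the target; on this read-out higher numbers stand for an effect only at larger amounts of compound and lower numbers for an effect already at smaller amounts.
Compound 2 `CCC(=O)N(c1cccc(Cl)c1)C1CCCC1N(C)C` gives 0.2 mg/kg in this assay.
Compound 3 `CCC(=O)N(c1ccc(C)c(Cl)c1)C1CCCC1N(C)C` gives 0.6 mg/kg in this assay.

Compound 1 and compound 2 are built from the same atoms joined differently; how their two cores differ is not broken down here. Their results in this assay are level at the digits given, and that lies within the scatter of the measurement, so nothing separates them.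

Compound 3 arises from compound 2 by one change, (methyl in place of hydrogen on an aromatic carbon). This step, a 3.0-fold higher number from compound 2 to compound 3 (0.48 log units; beyond the scatter), is beyond the scatter and counts as modest in size.

Compound 4 `CCC(=O)N(c1ccc(Cl)c(C)c1)C1CCCC1N(C)C` is not yet measured. It arises from compound 1 by methyl in place of hydrogen on an aromatic carbon. Among the compounds with values here, this is the same kind of change as the one from compound 2 to compound 3, but the surroundings differ: in compound 3 the new methyl sits para to the large group, whereas in compound 4 it sits meta to the large group. Within the data shown here, only the one measured step is available as a guide.

On that basis compound 4 is expected to follow compound 1 by a step of about a 2.5-fold higher number from compound 1 to compound 4 (0.40 log units; beyond the scatter), resting on the size of the step from compound 2 to compound 3 given as a 3.0-fold higher number from compound 2 to compound 3 (0.48 log units; beyond the scatter). Compound 4 is therefore estimated at 0.5 mg/kg, with a likely span from 0.2 mg/kg to 1.2 mg/kg.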

Compound 4, dose for half-maximal effect: 2 mg/kg
Beside the measured number, compound 4's estimate is 4.0-fold (0.60 log units) below it; measured number above the stated range.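

Putting methyl in place of hydrogen on an aromatic carbon of compound 1 gives a 10-fold higher number from compound 1 to compound 4 (1.00 log units; beyond the scatter) in this assay, so a larger dose is needed for the effect after this change on both cores, but the size of the step does not carry over from one core to the other: the same change on two cores in this assay, a 3.0-fold higher number (0.48 log units; beyond the scatter) from compound 2 to compound 3 and a 10-fold higher number (1.00 log units; beyond the scatter) from compound 1 to compound 4, 3.3-fold (0.52 log units) apart, beyond the scatter of two such steps The direction held in both pairs, yet two pairs are too few to make a rule, and within this small set a step measured on one core gives only a loose guide to the size of the same step on the other. The data do not show why the two steps differ, since the methyl of compound 4 sits ortho to a chloro group and meta to a large group, and the two pairs also differ in how their cores are joined, so these features cannot be told apart.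

The compounds shown leave open whether an ethyl or a methoxy group on the same aromatic carbon as the methyl of compound 4 would follow the same direction. They also leave open whether fluoro in place of the chloro group would change the size of the methyl step.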